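The source may hold more compounds than are shown below. What is called first, only, known or untested is meant among the compounds shown, and "the series" means these compounds.

Compound 1 `CCCCC(=O)Nc1ccc(N2CCN(c3ccc(OC[C@@H]4CO[C@@](Cn5cncn5)(c5ccc(Cl)cc5Cl)O4)cc3)CC2)cc1` gives 14100 nM in a functional assay on HepG2 cells (Homo sapiens) for inhibition, read by MTT assay, with a stated time of 48 h; a lower number here means a stronger inhibitor, a higher number a weaker inhibitor.
Compound 2 `O=C(CCc1ccccc1)Nc1ccc(N2CCN(c3ccc(OC[C@@H]4CO[C@@](Cn5cncn5)(c5ccc(Cl)cc5Cl)O4)cc3)CC2)cc1` gives 5340 nM in this assay.

Compound 2 stands lowest of the two numbers, its nearest neighbour being compound 1, which lies higher by the step of a 2.6-fold lower number from compound 1 to compound 2 (0.42 log units; beyond the scatter). Compound 3 `O=C(Nc1ccc(N2CCN(c3ccc(OC[C@@H]4CO[C@@](Cn5cncn5)(c5ccc(Cl)cc5Cl)O4)cc3)CC2)cc1)c1cccc(F)c1` is the next structure in the series, differing from compound 2 in one place: 3-fluorophenyl in place of phenethyl on a carbonyl carbon. Within the data shown here, no measured step covers this change directly; the single step seen so far, a 2.6-fold lower number from compound 1 to compound 2 (0.42 log units; beyond the scatter), altered the chain end while keeping the carbonyl and its chain, whereas the change to compound 3 removes the chain and puts the ring straight onto the carbonyl carbon. That step was modest, and nothing here shows how a ring placed directly on the carbonyl behaves. The expectation for compound 3 is therefore a number close to that of compound 2, with a wide range, corresponding to an expected step of a 1.1-fold higher number from compound 2 to compound 3 (0.05 log units; within the scatter). Compound 3 is estimated at 6000 nM, between 2000 nM and 18000 nM.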

Compound 3, half-maximal inhibitory concentration: 10800 nM
The estimate for compound 3 lay 1.8-fold (0.26 log units) below the measured number; the range from low to high includes it.
By their numbers in this assay, from the lowest: compound 2; then compounds 3 and 1 (each within the scatter of the next).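

In this assay, the carbonyl carbon is shown for the first time carrying a ring directly, and 3-fluorophenyl in place of phenethyl gives a 2.0-fold higher number from compound 2 to compound 3 (0.31 log units; beyond the scatter). A ring at this position does not by itself keep the lower number of compound 2: 3-fluorophenyl in place of butyl gives a 1.3-fold lower number from compound 1 to compound 3 (0.12 log units; within the scatter), which leaves compound 3 and compound 1 indistinguishable here. Nothing available offers an explanation for either step.

This change removes the chain and introduces the fluorine together, so the compounds shown leave open which of the two accounts for the step from phenethyl. Unsubstituted phenyl or benzyl on the carbonyl carbon would separate these two changes, and a longer chain ending in phenyl would show whether the trend continues beyond phenethyl.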